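One Hydroxy Fewer: Expecting Compound 4 in Cytotoxicity

The compounds below may be only part of what the source reports. "The series", "measured", "known", "first", "only" and "open" are said of these compounds alone.

Measured in a functional assay on HSC-2 cells (Homo sapiens) for cytotoxicity, read by MTT assay; a lower number here means a stronger inhibitor, a higher number a weaker inhibitor:
compound 1 `OC[C@H]1O[C@@H](O[C@H](CCc2ccc(O)cc2)C[C@H](O)CCc2ccc(O)c(O)c2)[C@H](O)[C@@H](O)[C@@H]1O` gives 155 ug/mL;
compound 2 `OC[C@H]1O[C@@H](O[C@H](CCc2ccc(O)c(O)c2)C[C@H](O)CCc2ccc(O)c(O)c2)[C@H](O)[C@@H](O)[C@@H]1O` gives 92 ug/mL;
compound 3 `COc1cc(CC[C@H](C[C@H](O)CCc2ccc(O)c(O)c2)O[C@@H]2O[C@H](CO)[C@@H](O)[C@H](O)[C@H]2O)ccc1O` gives 209 ug/mL.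

Compound 1 stands second highest of the three numbers, within the scatter of both compound 3 and compound 2. Compound 4 `OC[C@H]1O[C@@H](O[C@H](CCc2ccc(O)cc2)C[C@H](O)CCc2ccc(O)cc2)[C@H](O)[C@@H](O)[C@@H]1O` differs from compound 1 by hydrogen in place of hydroxy on an aromatic carbon. The relevant measured step runs the other way: a 1.7-fold lower number from compound 1 to compound 2 (0.23 log units; within the scatter). Removing a hydroxy might therefore be expected to raise the number by a comparable, modest amount, as also a 2.3-fold higher number from compound 2 to compound 3 (0.36 log units; beyond the scatter). Compound 4 is thus estimated at 230 ug/mL in this assay, with a range of 120 ug/mL to 450 ug/mL, meaning an expected step of a 1.5-fold higher number from compound 1 to compound 4 (0.17 log units; within the scatter).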

Compound 4, half-maximal inhibitory concentration: 157 ug/mL
Compound 4: the middle estimate sits 1.5-fold (0.17 log units) above what was measured, and the stated range covers the measured number.
By their numbers in this assay, from the lowest: compounds 2, 1, 4 and 3 (each within the scatter of the next, the first and the last beyond it).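

In this assay, the change from 3,4-dihydroxyphenyl to 4-hydroxyphenyl gives a 1.0-fold higher number from compound 1 to compound 4 (0.01 log units; within the scatter). For the compounds shown here, this shows that, at this position, the hydroxy ortho to the remaining hydroxy group can be replaced by hydrogen without a step beyond the scatter, and the earlier steps had not tested this ring. Nothing available here explains this result. The compounds shown leave open whether an amine or a fluorine at this position would also stay within the scatter of compound 1.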